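This account rests on a few compounds, and the source may have more. Where it says the series, first, only, none or still open, it means among the compounds named here.

Measured so far:
compound 1 `O=C(NCc1ccc(S(=O)(=O)c2ccccc2)cc1)N1Cc2ccncc2C1` gives 7.5 mL/min/kg
compound 2 `O=C(NCc1ccc(S(=O)(=O)C2CCN(C3COC3)CC2)cc1)N1Cc2ccncc2C1` gives 10 mL/min/kg

In an ADME assay on microsomes from liver (Homo sapiens) for pharmacokinetics, read by LC-MS, with a stated time of 60 min, tested at 1 uM (a lower number here means slower removal, a higher number faster removal of the compound), compound 2 at 10 mL/min/kg lies within the scatter of compound 1. The change to compound 3 `O=C(NCc1ccc(S(=O)(=O)N2CCC(N3CCCC3)CC2)cc1)N1Cc2ccncc2C1` is 4-(pyrrolidin-1-yl)piperidin-1-yl in place of 1-(oxetan-3-yl)piperidin-4-yl on a sulfonyl sulfur and sits on the same sulfonyl sulfur. Among the measured compounds shown here, only one measured step bears on this place, namely a 1.3-fold higher number from compound 1 to compound 2 (0.12 log units; within the scatter) and it stays within the scatter. For the measured compounds named here, the entering group has no measured precedent, and no step beyond the scatter is expected in this assay for this change. The estimated step is a 1.2-fold higher number from compound 2 to compound 3 (0.08 log units; within the scatter) and remains within the scatter. Compound 3 is expected at 12 mL/min/kg with an estimated range of 6.5 mL/min/kg to 20 mL/min/kg for this measurement.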

Compound 3, clearance: 6 mL/min/kg
Estimate against measurement, compound 3: 2.0-fold (0.30 log units) above, outside the stated range (below it).
By their numbers in this assay, from the lowest: compounds 3, 1 and 2 (each within the scatter of the next).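

In this assay, 4-(pyrrolidin-1-yl)piperidin-1-yl on the sulfonyl sulfur gives a 1.7-fold lower number from compound 2 to compound 3 (0.22 log units; within the scatter) and a 1.3-fold lower number from compound 1 to compound 3 (0.10 log units; within the scatter). A third group at this place, with a nitrogen of its ring now bound to the sulfonyl sulfur, therefore still yields no step beyond the scatter from either earlier group. The data offer no measured explanation for this result.

Still open, from the compounds shown here alone, is whether a group of another kind on the sulfonyl sulfur, such as a carboxylic acid or a short open alkyl chain, would also stay within the scatter of these three compounds.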